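Methyl on the Ring Nitrogen of Compound 2

The compounds below may be only part of what the source reports. "The series", "measured", "known", "first", "only" and "open" are said of these compounds alone.

Among the measured compounds shown here, compound 2 `O=C(Nc1ccc(Oc2ccnc3[nH]ccc23)c(F)c1)c1nn(-c2ccc(Cl)c(F)c2)ccc1=O` sits at the weaker end of the two compounds measured so far. For the measured compounds named here, in a functional assay on A549 cells (Homo sapiens) for cytotoxicity, read by MTT assay, with a stated time of 72 h (a higher number here means a weaker inhibitor, a lower number a stronger inhibitor), compound 2 gives 10300 nM, while compound 1 `O=C(Nc1ccc(Oc2ccnc3[nH]ccc23)cc1)c1nn(-c2ccc(Cl)c(F)c2)ccc1=O` gives 2580 nM; the single measured step, a 4.0-fold higher number from compound 1 to compound 2 (0.60 log units; beyond the scatter), separates them. Compound 3 `Cn1ccc2c(Oc3ccc(NC(=O)c4nn(-c5ccc(Cl)c(F)c5)ccc4=O)cc3F)ccnc21` differs from compound 2 by methyl in place of hydrogen on an aromatic nitrogen. Going by the values given here, no measured step touches this position: the only step in hand concerns a fluoro on a different aromatic carbon, so it offers no guide to the size or direction of this change. The expectation for compound 3 therefore rests on the value of compound 2 alone and carries a wide range. Compound 3 is expected to show a modest shift, a 1.9-fold higher number from compound 2 to compound 3 (0.29 log units; within the scatter), toward a higher number. The estimate for compound 3 in this assay is 20000 nM, within a range of 6000 nM to 70000 nM.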

Compound 3, half-maximal inhibitory concentration: > 60000 nM
Compound 3 ended at the assay's limit; the forecaster's own chance of this, stated with the estimate: 20%; at least 3.0-fold (0.47 log units) between middle value and limit.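

In this assay, among the compounds shown here, methyl in place of hydrogen on the aromatic nitrogen gives an at least 5.8-fold higher number from compound 2 to compound 3 (0.76 log units; beyond the scatter), so this position, which no earlier step touched, does respond to a change, and the change here leads to a weaker inhibitor. Of the three compounds shown, compound 3 alone lacks the hydrogen on this nitrogen. The full size of the step remains unknown, as compound 3 carries a limit and not a number: the limit of > 60000 nM in this assay, at which 1 of the 3 values shown sits.

The compounds shown carry only hydrogen or methyl on this nitrogen, which leaves open whether an ethyl group, a longer chain or a chain ending in an amine would behave as methyl does. As far as these compounds go, it also remains open whether methyl would give a similar step on compound 1, which lacks the fluoro group of compound 2.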